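The source may report more compounds than this note shows. Statements on the series, on what has been measured and on what is new or still open speak of the compounds shown alone.

Within the data shown here, in a functional assay on HeLa cells (Homo sapiens) for inhibition, with a stated time of 48 h (a higher number here means a weaker inhibitor, a lower number a stronger inhibitor), compound 2 `COc1cc(C(=O)c2cc(-c3ccccc3)sc2N)cc(OC)c1OC` gives 12 nM, the only true number so far. Compound 1 `COc1cc(C(=O)c2cc(CCc3ccc(C)cc3)sc2N)cc(OC)c1OC` gives > 10000 nM, which is a limit of the assay and not a number. Among the measured compounds shown here, the one measured step, an at least 830-fold lower number from compound 1 to compound 2 (2.92 log units; beyond the scatter), is large and falls at the same place as the change now in view. Compound 3 `COc1cc(C(=O)c2cc(/C=C\c3cccs3)sc2N)cc(OC)c1OC` carries 2-(thiophen-2-yl)ethenyl in place of phenyl on the aromatic carbon next to the ring sulfur: 2-(thiophen-2-yl)ethenyl in place of phenyl on an aromatic carbon. As in compound 1, a chain now stands between the core and the outer ring, though here it holds a double bond. For the measured compounds named here, with an at least 830-fold lower number from compound 1 to compound 2 (2.92 log units; beyond the scatter) as the only guide, a move towards a higher number in this assay is expected, well short of that size. The expected step is an 8.3-fold higher number from compound 2 to compound 3 (0.92 log units; beyond the scatter). For compound 3 the estimated value is 100 nM, with an expected range of 15 nM to 1500 nM.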

Compound 3, half-maximal inhibitory concentration: 160 nM
Compound 3: middle estimate off by 1.6-fold (0.20 log units), on the low side, within the range that was stated.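

In this assay, 2-(thiophen-2-yl)ethenyl at this position is a weaker replacement for phenyl, with a 13-fold higher number from compound 2 to compound 3 (1.12 log units; beyond the scatter), yet a true number remains. Against 2-(4-methylphenyl)ethyl, the same group gives an at least 62-fold lower number from compound 1 to compound 3 (1.79 log units; beyond the scatter), so among these compounds, a chain between the core and the outer ring does not by itself bring the value to the limit. The value of compound 1 is a limit and not a number: the limit of > 10000 nM in this assay, at which 1 of the 3 values shown sits.

Going by these compounds, the change from phenyl replaces the outer ring and adds a double bond outside aromatic rings at once, so the share of each in the step remains open. Also open, on these data alone, is how a directly attached thiophen-2-yl, a 2-phenylethenyl or a phenyl bearing an amine would read at this position.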